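Aryl groups on the alkoxy ether of the shared core

A few compounds are considered here, and "the series" means these few. Any claim that something is new, unique, unknown or untested is made for them only; others in the source may bear on it.

Measured so far:
- compound 1, `CCOC(=O)c1c(C)nc(-c2cccc(C#N)c2)n1OC`, gives 9130 nM in a functional assay on a cell-free system (plasma, Oryctolagus cuniculus) for inhibition, with stated times of 5 min, 1 min and 6 min; on this read-out higher numbers stand for weaker inhibition and lower numbers for stronger inhibition
- compound 2, `CCOC(=O)c1c(C)nc(-c2cccc(C#N)c2)n1OCc1ccncc1`, gives 6200 nM in this assay

Among the compounds with values here, compound 1 carries the highest of the two numbers in this assay; compound 2 stands nearest to it, and the only measured step, a 1.5-fold lower number from compound 1 to compound 2 (0.17 log units; within the scatter), lies within the scatter, so no order between the two can be claimed.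

Compound 3, `CCOC(=O)c1c(C)nc(-c2cccc(C#N)c2)n1OCc1cccc(C#N)c1`, is not yet measured. It differs from compound 1 by 3-cyanophenyl in place of hydrogen on a saturated chain carbon bound to an oxygen on an aromatic ring. Within the data shown here, the one step that bears on this change is a 1.5-fold lower number from compound 1 to compound 2 (0.17 log units; within the scatter), where a different six-membered aromatic ring entered at the same place and gave a number within the scatter of compound 1. Among the measured compounds shown here, no step in the set shows a change beyond the scatter, so for compound 3 a number close to that of compound 1 is expected, with the estimated step of a 1.4-fold lower number from compound 1 to compound 3 (0.15 log units; within the scatter) not exceeding the scatter. The estimate for compound 3 in this assay is 6500 nM, expected to fall between 2800 nM and 15000 nM.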

Compound 3, half-maximal inhibitory concentration: > 30000 nM
Compound 3: a limit, no number; the forecaster's own chance of this, stated with the estimate: 10%; at least 4.6-fold (0.66 log units) between middle value and limit.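

In this assay compound 3 gives a limit and not a number: the limit of > 30000 nM in this assay, at which 1 of the 3 values shown sits.

The saturated chain carbon bound to an oxygen on an aromatic ring does not accept every aryl group alike: 3-cyanophenyl in place of hydrogen brings an at least 3.2-fold higher number from compound 1 to compound 3 (0.51 log units; beyond the scatter), and 3-cyanophenyl in place of pyridin-4-yl brings an at least 4.8-fold higher number from compound 2 to compound 3 (0.68 log units; beyond the scatter). The earlier step, a 1.5-fold lower number from compound 1 to compound 2 (0.17 log units; within the scatter), showed no change at this place, so the identity of the entering ring counts here, not merely the presence of one.

As far as these compounds go, whether the step belongs to the nitrile or to the carbon ring stays open, and a plain phenyl at the same place would separate the two. From the compounds shown here alone, how far compound 3 lies from the others also stays open with only a limit in hand, as does the outcome for a pyridin-3-yl group.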